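This account rests on a few compounds, and the source may have more. Where it says the series, first, only, none or still open, it means among the compounds named here.

Three members of the series have numbers in a functional assay on A549 cells (Homo sapiens) for antiproliferative activity, read by MTT assay, with a stated time of 24 h; on this read-out higher numbers stand for weaker inhibition and lower numbers for stronger inhibition. Compound 1 `O=c1[nH]cc(S(=O)(=O)Nc2ccccc2-c2cn(-c3ccc(Cl)cc3)nn2)c(=O)[nH]1` gives 1180 nM. Compound 2 `O=c1[nH]cc(S(=O)(=O)Nc2cccc(-c3cn(-c4cccc(F)c4)nn3)c2)c(=O)[nH]1` gives 7200 nM, and compound 3 `Cc1ccc(-n2cc(-c3ccc(NS(=O)(=O)c4c[nH]c(=O)[nH]c4=O)cc3)nn2)cc1` gives 5560 nM. Compound 3 thus stands second highest of the three: its gap to compound 2 lies within the scatter, while compound 1 sits below it by a gap beyond the scatter. Compound 4 `O=c1[nH]cc(S(=O)(=O)Nc2ccc(-c3cn(-c4ccccc4Cl)nn3)cc2)c(=O)[nH]1` differs from compound 3 in one place: 2-chlorophenyl in place of 4-methylphenyl on an aromatic nitrogen, on an aromatic nitrogen of a five-membered aromatic ring with 3 nitrogen. Among the measured compounds shown here, no pair of measured compounds isolates this change, so its size is unknown. For compound 4 a small downward step is expected, estimated at 4000 nM with a range of 1500 nM to 10000 nM. The step this estimate means, a 1.4-fold lower number from compound 3 to compound 4 (0.14 log units; within the scatter), is expected to stay within the scatter.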

Compound 4, half-maximal inhibitory concentration: 2810 nM
For compound 4 the middle estimate is 1.4-fold (0.15 log units) above the measured one, and the stated range covers the measured number.
By their numbers in this assay, from the lowest: compound 1; then compounds 4, 3 and 2 (each within the scatter of the next, the first and the last beyond it).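

In this assay, among the compounds shown here, replacing 4-methylphenyl with 2-chlorophenyl on an aromatic nitrogen of the five-membered ring gives the first readable step at this position: a 2.0-fold lower number from compound 3 to compound 4 (0.30 log units; within the scatter). Within these two compounds, the position accepts this exchange of two groups with equal heavy-atom counts without a step beyond the scatter. No evidence on any property of these groups accompanies the step.

On these data alone, whether a benzyl group or an aminoalkyl chain on this nitrogen would give a step beyond the scatter remains open. As far as these compounds go, whether this exchange gives a similar step on other members also remains open.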